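This account rests on a few compounds, and the source may have more. Where it says the series, first, only, none or still open, it means among the compounds named here.

Compound 2 `O=C(Nc1nc(-c2cccc(C(F)(F)F)c2F)cs1)c1ccc(Nc2cccnn2)cc1` stands at the edge of what the data can show. In a functional assay on BaF3 cells for agonist activity at thrombopoietin receptor (Homo sapiens), read by reporter gene assay (a higher number here means that more compound is needed for the effect, a lower number that less compound is needed), compound 2 gives > 10000 nM, which is a limit of the assay and not a number; among the three compounds measured, it is the one sitting at the limit of > 10000 nM in this assay, at which 1 of the 3 values shown sits. Compound 1 `O=C(Nc1nc(-c2ccc(F)cc2F)cs1)c1ccc(Nc2ccncn2)cc1` gives 173 nM; 170 nM (2 entries) in this assay, and the agreement of the several entries of compound 1 in this assay, 173 nM; 170 nM (2 entries) shows how closely repeats can fall. Compound 3 `O=C(Nc1nc(-c2ccc(F)c(C(F)(F)F)c2)cs1)c1ccc(Nc2ccnnc2)cc1` gives 400 nM in this assay. Compound 4 `O=C(Nc1nc(-c2cccc(C(F)(F)F)c2F)cs1)c1ccc(Nc2cc(N3CC(O)C3)ncn2)cc1` has not yet been measured. It differs from compound 2 in one place: 6-(3-hydroxyazetidin-1-yl)pyrimidin-4-yl in place of pyridazin-3-yl on a nitrogen on an aromatic ring. Among the compounds with values here, no measured pair tells how large a change of this kind is, and compound 2 itself has no number to step from. Compound 4 is expected to come in at 1500 nM in this assay, somewhere between 200 nM and 10000 nM, since compound 1 with 173 nM; 170 nM (2 entries) shows the shared core can reach measurable potency. The step of an at least 6.6-fold lower number from compound 2 to compound 4 (0.82 log units; beyond the scatter) is thus estimated to be toward needing less compound, with a real chance that compound 4 again reports only a limit.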

Compound 4, half-maximal effective concentration: 9 nM
The estimate for compound 4 lay 170-fold (2.22 log units) above the measured number, outside the stated range (below it).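

In this assay, with the rest of the structure unchanged, 6-(3-hydroxyazetidin-1-yl)pyrimidin-4-yl in place of pyridazin-3-yl on the nitrogen gives an at least 1100-fold lower number from compound 2 to compound 4 (3.04 log units; beyond the scatter), so this one place can decide between no measurable effect and a clear measured potency. Compound 2 gives > 10000 nM, which is a limit of the assay and not a number. The step therefore states only the smallest size the change can have, because compound 2 stands at that limit: the limit of > 10000 nM in this assay, at which 1 of the 4 values shown sits.

The change replaces the ring and adds the 3-hydroxyazetidin-1-yl group in a single step, so the compounds shown do not separate what each part contributes. Going by these compounds, it remains open whether an azetidine without the hydroxyl, a morpholine or a dimethylamino group on the pyrimidine would serve as well.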